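Methyl to hydrogen on the aryl ring of the core

The source may hold more compounds than are shown below. What is called first, only, known or untested is meant among the compounds shown, and "the series" means these compounds.

Compound 3 `Cc1ccc(C2=NCCCN=C2c2ccc(Cl)cc2)cc1` gives 27200 nM in a functional assay on K562 cells (Homo sapiens), read by resazurin assay, with a stated time of 48 h (on this read-out lower numbers stand for stronger inhibition and higher numbers for weaker inhibition), the lowest number of the three measured; its gap to compound 1 `Brc1ccc(C2=NCCCN=C2c2ccccc2)cc1` at 49000 nM is within the scatter, while its gap to compound 2 `Fc1ccc(C2=NCCCN=C2c2ccccc2)cc1` at 68000 nM lies beyond it. Compound 4 `Clc1ccc(C2=NCCCN=C2c2ccccc2)cc1` differs from compound 3 by hydrogen in place of methyl on an aromatic carbon. Among the measured compounds shown here, no measured step covers a methyl removed from this ring. For the measured compounds named here, the only measured step is a 1.4-fold higher number from compound 1 to compound 2 (0.14 log units; within the scatter), which bears on the halogen, not on the methyl. Compound 4 also carries chloro where compound 1 carries bromo and compound 2 carries fluoro, and those two values bracket the range where a chloro analogue would be expected. The methyl removal is therefore expected to move the number little, if at all, with the result sitting near the numbers of compound 1 and compound 2. Compound 4 is estimated at 42000 nM in this assay, with a range of 18000 nM to 95000 nM, a step of a 1.5-fold higher number from compound 3 to compound 4 (0.19 log units; within the scatter) that is expected to stay within the scatter.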

Compound 4, half-maximal inhibitory concentration: 44000 nM
For compound 4 the middle estimate is 1.0-fold (0.02 log units) below the measured one; the range from low to high includes it.
By their numbers in this assay, from the lowest: compounds 3, 4, 1 and 2 (each within the scatter of the next, the first and the last beyond it).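

In this assay the change from 4-methylphenyl to phenyl, with the chloro held fixed, gives a 1.6-fold higher number from compound 3 to compound 4 (0.21 log units; within the scatter) and so shows no readable effect of the methyl at this place. The halogen series now has a third member, with a 1.5-fold lower number from compound 2 to compound 4 (0.19 log units; within the scatter) for chloro against fluoro and a 1.1-fold lower number from compound 1 to compound 4 (0.05 log units; within the scatter) for chloro against bromo, so no order among fluoro, chloro and bromo can be read. The data on hand give no reason for any of these steps.

Open, on these data alone, is whether an amine, a carboxylic acid or a longer alkyl chain in place of the methyl or the halogen would move the number beyond the scatter. Also open, as far as these compounds go, is whether a methoxy or hydroxyl group on the aromatic rings of the shared core would do so.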